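Diaminotriazine aryl series: methoxy to fluoro switch

The source may hold more compounds than are shown below. What is called first, only, known or untested is meant among the compounds shown, and "the series" means these compounds.

Measured so far:
compound 1 `COc1ccc(Br)cc1-c1nc(N)nc(N)n1`, 49%
compound 2 `CCOc1ccccc1-c1nc(N)nc(N)n1`, -5%
compound 3 `Nc1nc(N)nc(-c2cc(F)ccc2Cl)n1`, 78%

In a functional assay on the whole organism with Rattus norvegicus as the target, at a dose of 20 mg/kg by the intraperitoneal route (a higher number here means more inhibition at the dose given (going by the name of the read-out), a lower number less inhibition), compound 1 gives 49%, the second highest of the three numbers: compound 3 sits higher, beyond the scatter, and compound 2 lower, also beyond the scatter. Compound 4 `Nc1nc(N)nc(-c2cc(Br)ccc2F)n1` is not yet measured in this assay. It differs from compound 1 by fluoro in place of methoxy on an aromatic carbon, placed on an aromatic carbon of a six-membered aromatic ring of carbon only, ortho to a group of 8 heavy atoms and para to a bromo group. Going by the values given here, no step between two measured compounds covers this change. Compound 3 carries chloro at the ring position where compound 1 carries methoxy. The two alkoxy compounds, compound 1 and compound 2, give the lower values, while compound 3 gives 78%. A rise is therefore expected from compound 1 to compound 4, a number 17 percentage points higher from compound 1 to compound 4 (beyond the scatter), beyond the scatter. Compound 4 is estimated at 66%, with a range from 42% to 86%.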

Compound 4, a percentage reported as inhibition, in the whole organism at one dose (the size of the read-out at that dose, not a potency): 100%
For compound 4 the middle estimate is 34 percentage points below the measured one; measured number above the stated range.
By their numbers in this assay, from the lowest: compound 2; then compound 1; then compound 3; then compound 4.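

In this assay, fluoro in place of methoxy on the aromatic carbon ortho to a group of 8 heavy atoms gives a number 51 percentage points higher from compound 1 to compound 4 (beyond the scatter) with the para bromo group unchanged. The contrast between alkoxy and halogen compounds, until now seen only across compounds differing in more than one place, therefore rests on a single-place step. No measured evidence bears on the reason for this step.

This single step cannot separate a gain from fluoro from a gain through the loss of methoxy. On these data alone, a hydroxyl or an amine at this position would test that, and whether the step carries over without the bromo group also remains open.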